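The compounds below may be only part of what the source reports. "The series", "measured", "known", "first", "only" and "open" are said of these compounds alone.

In a functional assay on NCI-H1975 cells (Homo sapiens) for inhibition, with a stated time of 72 h (on this read-out higher numbers stand for weaker inhibition of growth and lower numbers for stronger inhibition of growth), compound 1 `CC(C)c1cc(C(=O)N(C)Cc2ccc(C(=O)NO)cc2)c(O)cc1O` gives 1700 nM, while compound 2 `CCN(Cc1ccc(C(=O)NO)cc1)C(=O)c1cc(C(C)C)c(O)cc1O` gives 7000 nM, the higher of the two numbers and so the weaker growth inhibition. Compound 3 `CCCCN(Cc1ccc(C(=O)NO)cc1)C(=O)c1cc(C(C)C)c(O)cc1O` has ethyl in place of hydrogen on a saturated chain carbon, two bonds along the chain from an amide-type nitrogen. Within the data shown here, the one measured step that bears on this is a similar extension of the same chain, a 4.1-fold higher number from compound 1 to compound 2 (0.61 log units; beyond the scatter). A further rise of similar size is therefore expected in this assay, though a single step is thin evidence. The expected step is a 1.9-fold higher number from compound 2 to compound 3 (0.27 log units; within the scatter). The estimated value for compound 3 is 13000 nM, with an expected range of 4000 nM to 40000 nM.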

Compound 3, concentration for 50% growth inhibition: 23600 nM
Beside the measured number, compound 3's estimate is 1.8-fold (0.26 log units) below it; the measured number falls inside the stated range.
By their numbers in this assay, from the lowest: compound 1; then compound 2; then compound 3.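

Lengthening the chain on the amide-type nitrogen goes on weakening growth inhibition in this assay: ethyl in place of hydrogen on the saturated chain carbon gives a 3.4-fold higher number from compound 2 to compound 3 (0.53 log units; beyond the scatter), so the loss does not stop at compound 2. Taken as a whole, propyl in place of hydrogen on the carbon bound to the amide-type nitrogen gives a 14-fold higher number from compound 1 to compound 3 (1.14 log units; beyond the scatter), a large step. Nothing available accounts for this trend.

Still open, from the compounds shown here alone, is how a chain ending in an amine or a carboxylic acid would compare. Going by these compounds, a branched isopropyl group on the same nitrogen is equally open.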